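Methoxy Added to the Aryl on the Saturated Ring Carbon

This account rests on a few compounds, and the source may have more. Where it says the series, first, only, none or still open, it means among the compounds named here.

Compound 1, `Cc1cc(O)c(C2=NN(c3ccc(S(N)(=O)=O)cc3)C(c3ccccc3)C2)cc1Cl`, in a functional assay on the whole organism (strain Wistar) for inhibition, with Rattus norvegicus as the target, read by paw edema, with stated times of 30 min and 5 h, at a dose of 20 mg/kg by the oral route; on this read-out higher numbers stand for more inhibition at the one dose given (going by the name of the read-out) and lower numbers for less inhibition: 60.3%
Compound 2, `Cc1cc(O)c(C2=NN(c3ccc(S(N)(=O)=O)cc3)C(c3ccccc3O)C2)cc1Cl`: 59.5%
Compound 3, `COc1ccc(C2CC(c3cc(Cl)c(C)cc3O)=NN2c2ccc(S(N)(=O)=O)cc2)cc1OC`: 68.3%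

Compound 3 holds the highest of the three numbers, yet its gaps to compound 1 and to compound 2 both lie within the scatter, so no ordering among the three can be claimed. Compound 4, `COc1ccc(C2CC(c3cc(Cl)c(C)cc3O)=NN2c2ccc(S(N)(=O)=O)cc2)c(OC)c1OC`, differs from compound 3 by methoxy in place of hydrogen on an aromatic carbon. Within the data shown here, the steps that bear on this are a number 8 percentage points higher from compound 1 to compound 3 (within the scatter) and a number 8.8 percentage points higher from compound 2 to compound 3 (within the scatter), both changes of the group on the saturated ring carbon, and a number 0.8 percentage points lower from compound 1 to compound 2 (within the scatter), another substituent placed on an aromatic carbon; none of them left the scatter. In this assay a step beyond the scatter is therefore not expected; the expected change is a number 1.7 percentage points higher from compound 3 to compound 4 (within the scatter). Compound 4 is estimated at 70%, within 58% to 80%.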

Compound 4, a percentage reported as inhibition, in the whole organism at one dose (the size of the read-out at that dose, not a potency): 88.1%
Compound 4: middle estimate off by 18.1 percentage points, on the low side; measured number above the stated range.
By their numbers in this assay, from the lowest: compounds 2, 1 and 3 (each within the scatter of the next); then compound 4.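

In this assay, among these compounds, methoxy on the aromatic carbon ortho to a large group gives the first step beyond the scatter, a number 19.8 percentage points higher from compound 3 to compound 4 (beyond the scatter). The 2,3,4-trimethoxyphenyl group also clears the scatter against the other two aryl groups on the saturated ring carbon, with a number 28.6 percentage points higher from compound 2 to compound 4 (beyond the scatter) and a number 27.8 percentage points higher from compound 1 to compound 4 (beyond the scatter), which 3,4-dimethoxyphenyl did not do. No evidence at hand bears on why this step is so large.

Open, as far as these compounds go, is whether the gain is specific to methoxy at this place. An amine or an ethoxy group there could settle that, and the compounds shown give no reading on either.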